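Replacing an amide on the dihydropyrimidinone core with an ester

The compounds below may be only part of what the source reports. "The series", "measured", "known", "first", "only" and "open" are said of these compounds alone.

Measured so far:
Compound 1 `CC1=C(C(=O)CC(C)C)C(c2cccs2)NC(=O)N1` — 43%
Compound 2 `CCN(CC)C(=O)C1=C(C)NC(=O)NC1c1cccs1` — 22%

Both compounds share one core and differ only in the group attached to a carbonyl carbon. In an assay on membranes from HEK293 cells for displacement of a labelled ligand from adenosine receptor A2b (Homo sapiens), read by scintillation counting, with a stated time of 30 min, tested at 1 uM (on this read-out lower numbers stand for less inhibition and higher numbers for more inhibition at the one concentration tested (going by the name of the read-out)), compound 1 gives 43%, and compound 2 gives 22%, the lower of the two numbers; the change a number 21 percentage points lower from compound 1 to compound 2 (beyond the scatter) shows that putting diethylamino in place of isobutyl cost inhibition beyond the usual scatter.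

Compound 3 `CCC(CC)OC(=O)C1=C(C)NC(=O)NC1c1cccs1` has not yet been measured. It differs from compound 2 at the same carbonyl carbon: (pentan-3-yl)oxy in place of diethylamino on a carbonyl carbon. Among the measured compounds shown here, the only measured step that speaks to this position is the one from compound 1 to compound 2, which was modest in size and went downward when the diethylamino group entered. Since compound 3 removes that same diethylamino group, the step from compound 2 to compound 3 is expected to go back upward, though with an ester rather than a ketone the size is uncertain, so the estimate is a number 13 percentage points higher from compound 2 to compound 3 (beyond the scatter). For compound 3 in this assay the expected value is 35%, with a likely range from 15% to 55%.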

Compound 3, a percentage reported as inhibition, at one concentration (the size of the read-out at that concentration, not a potency): 6%
For compound 3 the middle estimate is 29 percentage points above the measured one; measured number below the stated range.
By their numbers in this assay, from the lowest: compound 3; then compound 2; then compound 1.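

In this assay, putting (pentan-3-yl)oxy in place of diethylamino on the carbonyl carbon gives a number 16 percentage points lower from compound 2 to compound 3 (beyond the scatter) and does not restore the inhibition lost earlier. Removing the diethylamino group is therefore not enough by itself, and what enters in its place matters too: compared with the isobutyl group, the same ester group gives a number 37 percentage points lower from compound 1 to compound 3 (beyond the scatter), the largest gap among these three compounds, which places compound 1 at the top and compound 3 at the bottom of the series. The measurements show this order at a single concentration, but nothing available here explains why the three groups rank this way.

The compounds shown leave open whether the low number of compound 3 goes with the ester link itself or with the branched chain it carries, and a smaller group such as ethoxy or methoxy on the same carbonyl carbon would help separate the two. They also leave open how a free carboxylic acid, or an amide made from a simple amine such as methylamine, would compare with these three groups.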